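Decylamine series: amine-to-hydroxy swap at the chain end

The source may hold more compounds than are shown below. What is called first, only, known or untested is meant among the compounds shown, and "the series" means these compounds.

Measured so far in a physicochemical assay for lipophilicity; a lower number here means a more polar compound, a higher number a more lipophilic compound:
Compound 1 `CCCCCCCCC(O)CNCCO`: 2.14
Compound 2 `CCCCCCCCCCNCCN`: 2.71
Compound 3 `CCCCCCCCCCCCCCNCCN`: 4.5

Compound 2 stands second highest of the three numbers in this assay. Its nearest neighbour is compound 1, whose value is lower by an amount beyond the scatter; compound 3 lies furthest away, higher by a number 1.79 log units higher from compound 2 to compound 3 (beyond the scatter), a large step.

Compound 4 `CCCCCCCCCCNCCO` is not yet measured. It differs from compound 2 by hydroxy in place of amino on a saturated chain carbon, two bonds along the chain from an amine nitrogen. Among the compounds with values here, none of the measured steps covers this exchange: the one step in hand, from compound 2 to compound 3, is a chain extension and says nothing about an amino-to-hydroxy swap. Compound 1 carries the hydroxyethylamino end and gives a lower number than compound 2, but it also carries a hydroxy on its chain, so the two values cannot be split into one step. Within the data shown here, with no step that bears directly on the change, compound 4 is expected to sit close to compound 2, with a step of a number 0.09 log units higher from compound 2 to compound 4 (within the scatter), within the scatter. The estimate for compound 4 in this assay is 2.8, between 2.3 and 3.3.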

Compound 4, partition coefficient: 3.09
Compound 4: the middle estimate sits 0.29 log units below what was measured; measured number inside the range.
By their numbers in this assay, from the lowest: compound 1; then compound 2; then compound 4; then compound 3.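

In this assay the swap of amino for hydroxy, on a saturated chain carbon, two bonds along the chain from an amine nitrogen, now has its own reading: a number 0.38 log units higher from compound 2 to compound 4 (beyond the scatter) is the step for this exchange at this place. The hydroxy on the chain of compound 1 can also be read separately: hydrogen in place of hydroxy on a saturated chain carbon bound to two saturated chain carbons gives a number 0.95 log units higher from compound 1 to compound 4 (beyond the scatter) with the (2-hydroxyethyl)amino end unchanged, which separates the two differences that compound 1 and compound 2 carried together. No supporting data bear on the origin of either step.

Going by these compounds, each exchange rests on a single pair, so whether the amino-to-hydroxy step holds on the longer chain of compound 3 remains open. On these data alone, the readings in this assay for methoxy or a carboxylic acid at this place also remain open.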